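From compound 2 to compound 3 at the limit

The source may report more compounds than this note shows. Statements on the series, on what has been measured and on what is new or still open speak of the compounds shown alone.

In a functional assay with Oryctolagus cuniculus as the target (a higher number here means a weaker inhibitor, a lower number a stronger inhibitor), compound 2 `COc1ccc(-c2nc(C(=O)N3CCCCC3)sc2-c2ccc(OC)cc2)cc1` gives > 1000 nM, which is a limit. Compound 1 `COc1ccc(-c2nc(/N=C(\N)[N+]3(C)CCCCC3)sc2-c2ccc(OC)cc2)cc1` gives > 1000 nM, also a limit. Going by the values given here, the only measured step is a step that the two limits leave unreadable from compound 1 to compound 2. The evidence so far is the limit of > 1000 nM in this assay, at which 2 of the 2 values shown sit. Compound 3 `CCOC(=O)/C(C#N)=C/c1nc(-c2ccc(OC)cc2)c(-c2ccc(OC)cc2)s1` carries 2-cyano-2-(ethoxycarbonyl)ethenyl in place of (piperidin-1-yl)carbonyl on an aromatic carbon. No readable step bears on this change, so no direction is supported and the series is expected to stay near its limit. The expected step is a step that the limit leaves unreadable from compound 2 to compound 3. For compound 3 the estimate is 2000 nM, with an expected range from 200 nM to 20000 nM.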

Compound 3, half-maximal inhibitory concentration: < 10 nM
Compound 3: only a limit was reported; the forecaster's own chance of this, stated with the estimate: 65%; at least 200-fold (2.30 log units) between middle value and limit.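

At this position, next to the ring nitrogen and the ring sulfur, the shared core can give a strong read-out in this assay: 2-cyano-2-(ethoxycarbonyl)ethenyl in place of (piperidin-1-yl)carbonyl gives an at least 100-fold lower number from compound 2 to compound 3 (2.00 log units; beyond the scatter). The same group also gives an at least 100-fold lower number from compound 1 to compound 3 (2.00 log units; beyond the scatter), whereas the earlier step between the two limits cannot be read. Compound 3 gives < 10 nM, which is a limit.

Which part of the entering group matters remains open, since nitrile and ethyl ester appear only together. A carboxylic acid in place of the ester would be one test.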